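Swapping an Acetamido for a Thiophene Ester: Cytotoxicity Outlook

This account rests on a few compounds, and the source may have more. Where it says the series, first, only, none or still open, it means among the compounds named here.

Three close relatives sharing one core have been tested in an ADME assay on Vero cells (Chlorocebus sabaeus) for cytotoxicity, read by MTT assay, with a stated time of 48 h; a higher number here means a weaker inhibitor, a lower number a stronger inhibitor. Compound 1 `O=C(OC1CCC(CN2CCN(c3cc(=O)c4cc(C(F)(F)F)cc([N+](=O)[O-])c4s3)CC2)CC1)C1CCCCC1` carries a (cyclohexylcarbonyl)oxy group on its saturated six-membered ring. In this assay compound 1 reaches only the limit of > 64 ug/mL. Compound 2 `O=c1cc(N2CCN(CC3CCC(OS(=O)(=O)c4cccnc4)CC3)CC2)sc2c([N+](=O)[O-])cc(C(F)(F)F)cc12` has a (pyridin-3-yl)sulfonyl in place of cyclohexylcarbonyl on an oxygen on a saturated carbon. In this assay compound 2 also stops at the limit of > 64 ug/mL. Compound 3 `CC(=O)NC1CCC(CN2CCN(c3cc(=O)c4cc(C(F)(F)F)cc([N+](=O)[O-])c4s3)CC2)CC1` bears an acetamido in place of (cyclohexylcarbonyl)oxy on a saturated ring carbon. In this assay compound 3 likewise shows only the limit of > 64 ug/mL. So compound 3 stands exactly where every measured value stands, (the limit of > 64 ug/mL in this assay, at which 3 of the 3 values shown sit). All three steps are thus unreadable: a step that the two limits leave unreadable from compound 1 to compound 2, a step that the two limits leave unreadable from compound 1 to compound 3 and a step that the two limits leave unreadable from compound 2 to compound 3.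

Compound 4 `O=C(OC1CCC(CN2CCN(c3cc(=O)c4cc(C(F)(F)F)cc([N+](=O)[O-])c4s3)CC2)CC1)c1cccs1` differs from compound 3 as follows: ((thiophen-2-yl)carbonyl)oxy in place of acetamido on a saturated ring carbon. Among the compounds with values here, no measured step bears on this change in a readable way, and none shows any compound moving off the limit. The expected step is therefore a step that the limit leaves unreadable from compound 3 to compound 4, meaning no movement beyond the scatter. Compound 4 is estimated at 90 ug/mL, within 45 ug/mL to 250 ug/mL, and most likely reported once more only as a limit.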

Compound 4, half-maximal inhibitory concentration: > 64 ug/mL
Compound 4 gave a limit, no number; the forecaster's own chance of this, stated with the estimate: 85%; the middle value lies beyond the limit too.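

Compound 4, like compound 1, compound 2 and compound 3, returns only a limit, so no step among these four compounds can be read: the limit of > 64 ug/mL in this assay, at which 4 of the 4 values shown sit.

The compounds shown leave open what actual number any of the four would give in this assay, and whether swapping the groups on the saturated ring changes that number at all.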